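The source may hold more compounds than are shown below. What is called first, only, known or untested is meant among the compounds shown, and "the series" means these compounds.

Measured compounds:
Compound 1, `COc1ccccc1-c1ccccc1NC(=O)[C@@H]1CCCN1C(=O)CCc1nc2ccccc2[nH]1`, gives 2 nM in an assay on CHO cells for displacement of a labelled ligand from Orexin receptor type 2 (Homo sapiens); on this read-out lower numbers stand for stronger inhibition and higher numbers for weaker inhibition.
Compound 2, `Cn1c(SCC(=O)N2CCC[C@H]2C(=O)Nc2ccccc2-c2ccccc2)nc2ccccc21`, gives 0.2 nM in this assay.

Compound 1 stands at the higher of the two numbers; compound 2 sits a full order lower, a gap beyond the scatter. Compound 3, `O=C(Nc1ccccc1-n1cccc1)[C@@H]1CCCN1C(=O)CCc1nc2ccccc2[nH]1`, has not been measured. It differs from compound 1 by 1H-pyrrol-1-yl in place of 2-methoxyphenyl on an aromatic carbon. Among the compounds with values here, no measured pair shows this change, so the step from compound 1 to compound 3 is estimated to be a moderate rise in the number, a 3.0-fold higher number from compound 1 to compound 3 (0.48 log units; beyond the scatter). The value of compound 3 is therefore expected to be 6 nM, with a plausible range from 1.5 nM to 25 nM.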

Compound 3, inhibition constant: 11 nM
For compound 3 the middle estimate is 1.8-fold (0.26 log units) below the measured one; measured number inside the range.
By their numbers in this assay, from the lowest: compound 2; then compound 1; then compound 3.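

Within the data shown here, exchanging 2-methoxyphenyl for 1H-pyrrol-1-yl on this aromatic carbon, ortho to a large group, gives a 5.5-fold higher number from compound 1 to compound 3 (0.74 log units; beyond the scatter), the first evidence that this position responds to the group it carries. The two groups have the same counts of hydrogen-bond donors and acceptors and no net charge, so the rise comes with a smaller group whose ring holds a hetero atom, and those counts do not account for it. Nothing measured here explains the rise. Going by these compounds, it remains open how a 2-pyridyl ring or a small amine would fare at this position. On these data alone, it also remains open whether this step would carry over to the core of compound 2.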